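Series notes: the benzyloxy group in this assay

This account rests on a few compounds, and the source may have more. Where it says the series, first, only, none or still open, it means among the compounds named here.

Compound 2 `COc1ccccc1COc1ccccc1OCCNCCOc1c(OC)cccc1OC` is the weaker of the two measured compounds in an assay on CHO cells for displacement of a labelled ligand from Alpha-1B adrenergic receptor (Homo sapiens) (a higher number here means a weaker inhibitor, a lower number a stronger inhibitor), where compound 2 gives 6.31 nM. Among the compounds with values here, its only measured neighbour is compound 1 `COc1cccc(OC)c1OCCNCCOc1ccccc1OCc1cccc(Cl)c1`, which gives 0.159 nM, so compound 2 stands at the high end of the numbers seen so far, with the step of a 40-fold higher number from compound 1 to compound 2 (1.60 log units; beyond the scatter) separating the two.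

Compound 3 `COc1cccc(COc2ccccc2OCCNCCOc2c(OC)cccc2OC)c1` differs from compound 2 only in the benzyloxy group: 3-methoxyphenyl in place of 2-methoxyphenyl on a saturated chain carbon bound to an oxygen on an aromatic ring. Within the data shown here, the one measured step bears on this place: from compound 1 to compound 2 the 3-chlorophenyl was replaced by 2-methoxyphenyl at the same saturated chain carbon, and the number rose by a 40-fold higher number from compound 1 to compound 2 (1.60 log units; beyond the scatter). Compound 3 carries its substituent, like compound 1, at the 3-position of the phenyl, though as methoxy rather than chlorine. The expectation is therefore a drop in this assay, but a smaller one than the full reversal of that step, since the group itself also changes.

Compound 3 is estimated at 1 nM (range 0.2 nM to 5 nM), an expected step of a 6.3-fold lower number from compound 2 to compound 3 (0.80 log units; beyond the scatter).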

Compound 3, inhibition constant: 2 nM
For compound 3 the middle estimate is 2.0-fold (0.30 log units) below the measured one; measured number inside the range.
By their numbers in this assay, from the lowest: compound 1; then compound 3; then compound 2.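

Moving the methoxy group alone, with the atoms unchanged, shifts the result in this assay: going from 2-methoxyphenyl to 3-methoxyphenyl gives a 3.2-fold lower number from compound 2 to compound 3 (0.50 log units; beyond the scatter). The attachment point of the substituent on the phenyl ring carried by the saturated chain carbon therefore matters by itself, which the earlier step could not show, since a 40-fold higher number from compound 1 to compound 2 (1.60 log units; beyond the scatter) changed both the group and its attachment point. With the attachment point held, methoxy in place of chloro on an aromatic carbon gives a 13-fold higher number from compound 1 to compound 3 (1.10 log units; beyond the scatter), so the group change is the larger of the two parts in this assay, and no measured evidence on the origin of either step is available here.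

The compounds shown leave open whether the same shift in attachment point would hold for chlorine, which 2-chlorophenyl at this saturated chain carbon would test against the 3-chlorophenyl of compound 1. They also leave open how the substituted groups compare with an unsubstituted phenyl, or with a 3-methylphenyl or a 3-fluorophenyl, so the trend from chloro to methoxy rests on a single pair.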